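From a bromophenyl to a pyridinyl on the chain end

The compounds below may be only part of what the source reports. "The series", "measured", "known", "first", "only" and "open" are said of these compounds alone.

For the measured compounds named here, compound 2 `COc1cc(/C=C/c2ccc(NC(=O)/C=C/c3ccc(Br)cc3)cc2)cc(OC)c1` is the only compound here with a number in a functional assay on MDA-MB-231 cells (Homo sapiens) for inhibition, read by MTT assay, with a stated time of 48 h (a lower number here means a stronger inhibitor, a higher number a weaker inhibitor), giving 6160 nM. Compound 1 `COc1cc(/C=C/c2ccc(NC(=O)/C=C/c3ccc(F)cc3F)cc2)cc(OC)c1` reaches only the limit > 20000 nM in this assay. The step of an at least 3.2-fold lower number from compound 1 to compound 2 (0.51 log units; beyond the scatter) shows an at least modest gain on changing the aryl group. Compound 3 `COc1cc(/C=C/c2ccc(NC(=O)/C=C/c3ccccn3)cc2)cc(OC)c1` differs from compound 2 by pyridin-2-yl in place of 4-bromophenyl on a double-bonded chain carbon bound to a double-bonded chain carbon. That single measured step concerns a different pair of aryl groups, so it gives no firm direction for compound 3, for which a modest loss is expected, a 1.9-fold higher number from compound 2 to compound 3 (0.29 log units; within the scatter). Compound 3 is therefore estimated at 12000 nM, between 4000 nM and 40000 nM.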

Compound 3, half-maximal inhibitory concentration: 3400 nM
Compound 3: middle estimate off by 3.5-fold (0.55 log units), on the high side, outside the stated range (below it).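

In this assay a ring with a hetero atom is accepted at this place: pyridin-2-yl and 4-bromophenyl do not separate (a 1.8-fold lower number from compound 2 to compound 3 (0.26 log units; within the scatter)). Pyridin-2-yl also stands clear of 2,4-difluorophenyl (an at least 5.8-fold lower number from compound 1 to compound 3 (0.76 log units; beyond the scatter)), so bromine is not needed for the gain seen earlier. Compound 1 gives a limit and not a number, so that step has no fixed size: the limit of > 20000 nM in this assay, at which 1 of the 3 values shown sits.

The compounds shown leave open whether the ring nitrogen itself counts, which a plain phenyl or another pyridinyl isomer would address. They also leave open how a saturated ring such as piperidinyl would fare here.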